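Phenol methylation on the bis-nitrate cinnamate of compound 2

The source may report more compounds than this note shows. Statements on the series, on what has been measured and on what is new or still open speak of the compounds shown alone.

Measured in a functional assay on HeLa cells (Homo sapiens) for cytotoxicity, read by resazurin assay, with a stated time of 72 h; on this read-out lower numbers stand for stronger inhibition and higher numbers for weaker inhibition:
compound 1, `COc1cc(/C=C/C(=O)OC(C)CCOc2no[n+]([O-])c2S(=O)(=O)c2ccccc2)ccc1O`, 400 nM
compound 2, `O=C(/C=C/c1ccc(OCCCCCO[N+](=O)[O-])c(O)c1)OCCCCCO[N+](=O)[O-]`, 5730 nM
compound 3, `O=C(/C=C/c1ccc(O)c(O)c1)OCc1c(-c2ccccc2)no[n+]1[O-]`, 1230 nM

On this read-out compound 2 stands highest of the three numbers. Compound 3 lies nearest, and the gap is beyond the scatter; compound 1 lies furthest, again beyond the scatter. Both of those compounds differ from compound 2 in more than one place, so no single change can be credited for either gap.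

Compound 4, `COc1cc(/C=C/C(=O)OCCCCCO[N+](=O)[O-])ccc1OCCCCCO[N+](=O)[O-]`, differs from compound 2 by methyl in place of hydrogen on an oxygen on an aromatic ring. Among the compounds with values here, no measured pair isolates this change. Compound 1 carries a methoxy, but its ester portion is unrelated, so its number is not a guide to the step. The expected step is a 1.3-fold lower number from compound 2 to compound 4 (0.10 log units; within the scatter), probably within the scatter. Compound 4 is estimated at 4500 nM, with a range from 1500 nM to 13000 nM.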

Compound 4, half-maximal inhibitory concentration: > 50000 nM
Compound 4 ended at the assay's limit; the forecaster's own chance of this, stated with the estimate: 5%; middle value at least 11-fold (1.04 log units) away from the limit.
By their numbers in this assay, from the lowest: compound 1; then compound 3; then compound 2. At a limit, above all of these: compound 4.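

In this assay, within the data shown here, hydroxy to methoxy on the aromatic ring of compound 2 gives an at least 8.7-fold higher number from compound 2 to compound 4 (0.94 log units; beyond the scatter), the only single-place step in this set. This oxygen therefore tolerates methyl poorly in the bis-nitrate cinnamate. The true size of the step cannot be read, only its lower bound, as compound 4 stands at a limit of the assay: the limit of > 50000 nM in this assay, at which 1 of the 4 values shown sits.

Still open, going by these compounds, is whether an ethyl group or a longer chain on this oxygen, or an amine in place of the hydroxy, would behave the same way. On these data alone, it is also open whether the step carries over to the ester portions of compound 1 and compound 3.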